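The compounds below may be only part of what the source reports. "The series", "measured", "known", "first", "only" and "open" are said of these compounds alone.

Measured so far in a functional assay on SW480 cells (Homo sapiens) for antiproliferative activity, read by MTT assay, with a stated time of 48 h; a lower number here means a stronger inhibitor, a higher number a weaker inhibitor:
compound 1 `CC(C)=CCC[C@]1(C)/C=C/[C@@H](OC(=O)C=C(C)C)[C@](C)(O)/C=C/C(=O)/C(CN2CCCC2)=C\C1`: 310 nM
compound 2 `CC(C)=CCC[C@]1(C)/C=C/[C@@H](OC(=O)C=C(C)C)[C@](C)(O)/C=C/C(=O)/C(C[Si](c2ccccc2)(c2ccccc2)C(C)(C)C)=C\C1`: 20700 nM
compound 3 `CC(C)=CCC[C@]1(C)/C=C/[C@@H](OC(=O)C=C(C)C)[C@](C)(O)/C=C/C(=O)/C(COC(=O)c2ccc([N+](=O)[O-])cc2)=C\C1`: 570 nM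

Compound 1 stands level with compound 3 at the low, stronger end of these numbers. The measured difference between them is a 1.8-fold higher number from compound 1 to compound 3 (0.26 log units; within the scatter), so the two cannot be told apart. Compound 2 lies far higher than either.

The next compound is compound 4 `CO/N=C/C1=C/C[C@](C)(CCC=C(C)C)/C=C/[C@@H](OC(=O)C=C(C)C)[C@](C)(O)/C=C/C1=O`, which has not yet been measured. Its change from compound 1 is a group of 4 heavy atoms (2 carbon, 1 nitrogen, 1 oxygen; no ring) in place of a group of 6 heavy atoms (5 carbon, 1 nitrogen; one five-membered non-aromatic ring with 1 hetero atom), on a double-bonded ring carbon: (pyrrolidin-1-yl)methyl leaves the ring carbon and a small open-chain group without a ring enters.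

The closest guide is the swap of pyrrolidin-1-yl for ((4-nitrophenyl)carbonyl)oxy, which gave a 1.8-fold higher number from compound 1 to compound 3 (0.26 log units; within the scatter). That suggests change in this part of the molecule can be tolerated, but compound 2 goes against this, so the range must stretch upward.

The expected size of the change is a 1.9-fold higher number from compound 1 to compound 4 (0.29 log units; within the scatter). For compound 4 the estimated value is 600 nM, with an expected range of 200 nM to 3000 nM.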

Compound 4, half-maximal inhibitory concentration: 2630 nM
Estimate against measurement, compound 4: 4.4-fold (0.64 log units) below; low and high end bracket the measured number.
By their numbers in this assay, from the lowest: compounds 1 and 3 (each within the scatter of the next); then compound 4; then compound 2.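

In this assay, putting the small open-chain group with its nitrogen and oxygen on this double-bonded ring carbon, in place of (pyrrolidin-1-yl)methyl, gives an 8.5-fold higher number from compound 1 to compound 4 (0.93 log units; beyond the scatter) and so shows a real loss among compounds that differ in this one place. Compound 3 gave no such sign, with a 1.8-fold higher number from compound 1 to compound 3 (0.26 log units; within the scatter), so the comparison with compound 1 now shows that the outcome at this position depends on which group enters. No measurement on hand gives a reason for this loss.

On these data alone, it remains open whether another ring amine, such as morpholine or piperidine, would stay level with compound 1. As far as these compounds go, it is also open whether a longer chain on the oxygen of the new group, such as ethyl or benzyl in place of its methyl, would shift the number in either direction.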